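Swapping the hydroxyazetidine of compound 1 for a pyrrolidine

This account rests on a few compounds, and the source may have more. Where it says the series, first, only, none or still open, it means among the compounds named here.

Compound 1, `Cc1c(C(=O)O)c(-c2cccc(N3CCN(c4ccc(NS(=O)(=O)c5ccc(N[C@H](CCN6CC(O)C6)CSc6ccccc6)c(S(=O)(=O)C(F)(F)F)c5)cc4)CC3)c2)c(-c2ccc(Cl)cc2)n1C`, is the weaker of the two measured compounds: in a functional assay on NCI-H146 cells (Homo sapiens) for inhibition, read by WST assay, with a stated time of 4 days (a higher number here means a weaker inhibitor, a lower number a stronger inhibitor), compound 1 gives 241 nM. Compound 2, `CCn1c(C)c(C(=O)O)c(-c2cccc(N3CCN(c4ccc(NS(=O)(=O)c5ccc(N[C@H](CCN6CCC(O)CC6)CSc6ccccc6)c(S(=O)(=O)C(F)(F)F)c5)cc4)CC3)c2)c1-c1ccc(Cl)cc1`, gives 22 nM in this assay, a clearly lower number, but compound 2 differs from compound 1 in more than one place, so the two values alone do not show which change matters. Compound 3, `Cc1c(C(=O)O)c(-c2cccc(N3CCN(c4ccc(NS(=O)(=O)c5ccc(N[C@H](CCN6CCCC6)CSc6ccccc6)c(S(=O)(=O)C(F)(F)F)c5)cc4)CC3)c2)c(-c2ccc(Cl)cc2)n1C`, has not been measured. It differs from compound 1 in one place: pyrrolidin-1-yl in place of 3-hydroxyazetidin-1-yl on a saturated chain carbon, three bonds along the chain from a nitrogen on an aromatic ring. Among the measured compounds shown here, no measured pair shows this change on its own, and compound 2 carries a different ring, so no direct guide exists. The change is expected to shift the number little, perhaps towards a somewhat lower value, as the step of a 1.6-fold lower number from compound 1 to compound 3 (0.21 log units; within the scatter). Compound 3 is therefore expected to give about 150 nM in this assay, within a range from 40 nM to 600 nM.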

Compound 3, half-maximal inhibitory concentration: 87 nM
Beside the measured number, compound 3's estimate is 1.7-fold (0.24 log units) above it, and the stated range covers the measured number.
By their numbers in this assay, from the lowest: compound 2; then compound 3; then compound 1.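

Read on its own in this assay, pyrrolidin-1-yl in place of 3-hydroxyazetidin-1-yl on this saturated chain carbon gives a 2.8-fold lower number from compound 1 to compound 3 (0.44 log units; beyond the scatter), so the ring at this position affects the number even with the rest of the molecule held fixed. The entering group has no hydrogen-bond donor, which shows that a donor in this group is not required for the lower number seen here. Nothing available bears on why the number moves.

This single step changes the ring size and removes the hydroxyl group together, leaving open which of the two accounts for the shift. A comparison with azetidin-1-yl, which keeps the four-membered ring without the hydroxyl group, or with 3-hydroxypyrrolidin-1-yl, which keeps the five-membered ring with it, could separate the two.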